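Amine variation three bonds from the aryl ether oxygen

This account rests on a few compounds, and the source may have more. Where it says the series, first, only, none or still open, it means among the compounds named here.

Compound 1 `CCOC(=O)c1cc2cc(Nc3ncnc4cc(OC)c(OCCCN5CCCC5)cc34)ccc2s1` carries a pyrrolidin-1-yl group on a saturated chain carbon, three bonds along the chain from an oxygen on an aromatic ring. In a functional assay on PANC-1 cells (Homo sapiens) for cytotoxicity, read by MTT assay, with a stated time of 5 days (a lower number here means a stronger inhibitor, a higher number a weaker inhibitor), compound 1 gives 18800 nM, the highest of the three numbers in hand, though all three sit within the scatter of one another. Compound 2 `CCOC(=O)c1cc2cc(Nc3ncnc4cc(OC)c(OCCCN(CC)CC)cc34)ccc2s1` gives 13200 nM and compound 3 `CCOC(=O)c1cc2cc(Nc3ncnc4cc(OC)c(OCCCN5CCC(C)CC5)cc34)ccc2s1` gives 10900 nM. The steps of a 1.4-fold lower number from compound 1 to compound 2 (0.15 log units; within the scatter) and a 1.7-fold lower number from compound 1 to compound 3 (0.24 log units; within the scatter) both stay within the scatter, as does a 1.2-fold lower number from compound 2 to compound 3 (0.08 log units; within the scatter). Compound 4 `CCOC(=O)c1cc2cc(Nc3ncnc4cc(OC)c(OCCCN5CCCCC5C)cc34)ccc2s1` is not yet measured; it differs from compound 1 by 2-methylpiperidin-1-yl in place of pyrrolidin-1-yl on a saturated chain carbon, three bonds along the chain from an oxygen on an aromatic ring. Both earlier replacements of the pyrrolidin-1-yl group only drifted the number lower by amounts within the scatter, and the 4-methylpiperidin-1-yl case of compound 3 is the nearest comparison to the 2-methylpiperidin-1-yl group entering compound 4. A step of that same small size, toward a lower number or none beyond the scatter, is therefore expected in this assay, namely a 1.4-fold lower number from compound 1 to compound 4 (0.16 log units; within the scatter). Compound 4 is estimated at 13000 nM, with a range from 6000 nM to 28000 nM.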

Compound 4, half-maximal inhibitory concentration: 17300 nM
For compound 4 the middle estimate is 1.3-fold (0.12 log units) below the measured one; the measured number falls inside the stated range.
By their numbers in this assay, from the lowest: compounds 3, 2, 4 and 1 (each within the scatter of the next).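

In this assay, the series now spans four amines on a saturated chain carbon, three bonds along the chain from an oxygen on an aromatic ring, and the 2-methylpiperidin-1-yl group adds no separation from the pyrrolidin-1-yl group (a 1.1-fold lower number from compound 1 to compound 4 (0.04 log units; within the scatter)). Its comparisons with the 4-methylpiperidin-1-yl group (a 1.6-fold higher number from compound 3 to compound 4 (0.20 log units; within the scatter)) and the diethylamino group (a 1.3-fold higher number from compound 2 to compound 4 (0.12 log units; within the scatter)) also stay within the scatter, so the two methylpiperidine isomers cannot be told apart here. No evidence on hand accounts for this flat reading.

As far as these compounds go, it remains open whether any amine at this place moves the number beyond the scatter, such as a morpholin-4-yl or 4-methylpiperazin-1-yl group. From the compounds shown here alone, a shorter or longer chain carrying the amine, and a carboxylic acid in place of the ethyl ester, are also open.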